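A few compounds are considered here, and "the series" means these few. Any claim that something is new, unique, unknown or untested is made for them only; others in the source may bear on it.

Measured compounds in a functional assay on A549 cells (Homo sapiens) for inhibition, read by MTT assay, with a stated time of 48 h; on this read-out lower numbers stand for stronger inhibition and higher numbers for weaker inhibition:

Compound 1 `COc1ccc(CNC(=O)/C=C/c2coc3cc(O)ccc3c2=O)cc1`: compound 1 gives > 100000 nM, which is a limit of the assay and not a number.
Compound 2 `COc1ccc2c(=O)c(/C=C/C(=O)Nc3ccccc3Cl)coc2c1`: compound 2 gives 29900 nM.
Compound 3 `COc1ccc(NC(=O)/C=C/c2coc3cc(O)ccc3c2=O)cc1`: compound 3 gives 12800 nM.

Compound 2 stands at the highest of the two numbers in this assay. The nearest is compound 3, whose number is lower by a gap beyond the usual scatter. The third entry, compound 1, is a limit only (the limit of > 100000 nM in this assay, at which 1 of the 3 values shown sits), so it sets no number against which compound 2 can be ordered.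

Compound 4 `COc1ccc2c(=O)c(/C=C/C(=O)Nc3ccc(F)cc3)coc2c1` has not yet been measured in this assay. It differs from compound 2 by 4-fluorophenyl in place of 2-chlorophenyl on an amide-type nitrogen. Among the measured compounds shown here, no pair among the measured compounds carries this change or one of the same kind, so nothing measured here points to a direction for the step. The expectation is a step of no clear direction, not beyond the scatter. For compound 4 the estimated value in this assay is 30000 nM, with an expected range from 10000 nM to 100000 nM. This estimate means an expected step of a 1.0-fold higher number from compound 2 to compound 4 (0.00 log units; within the scatter) that stays within the scatter.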

Compound 4, half-maximal inhibitory concentration: 26800 nM
Compound 4: middle estimate off by 1.1-fold (0.05 log units), on the high side, and the stated range covers the measured number.
By their numbers in this assay, from the lowest: compound 3; then compounds 4 and 2 (each within the scatter of the next). At a limit, above all of these: compound 1.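

In this assay, among the compounds shown here, 4-fluorophenyl in place of 2-chlorophenyl on an amide-type nitrogen gives a 1.1-fold lower number from compound 2 to compound 4 (0.05 log units; within the scatter), the first step between compounds that differ in one place. For the compounds shown here, on this read-out the two halogenated phenyl groups are therefore interchangeable at this place, although the single pair cannot separate the exchange of chlorine for fluorine from the shift in where the halogen sits on the ring. Nothing measured bears on why the two groups read alike.

Still open, as far as these compounds go, is whether a different group on that nitrogen, such as a pyridine ring or a phenyl ring carrying a carboxylic acid, would move the number beyond the scatter. Also open, from the compounds shown here alone, is whether the same exchange reads alike on the core of compound 3.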